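Replacing the Anilino Group with Piperidine on the Quinone Core

The compounds below may be only part of what the source reports. "The series", "measured", "known", "first", "only" and "open" are said of these compounds alone.

Among the compounds with values here, compound 1 `CCc1ccc(NC2=CC(=O)c3nc4n(c3C2=O)[C@H]2OC[C@@H](O)[C@H]2OC4)cc1` holds the only actual number in a functional assay on MCF7 cells (Homo sapiens) for inhibition, read by sulforhodamine B assay; on this read-out lower numbers stand for stronger inhibition and higher numbers for weaker inhibition: in this assay compound 1 gives 960 nM. Compound 2 `O=C1C=C(Nc2ccc(C(F)(F)F)cc2)C(=O)c2c1nc1n2[C@H]2OC[C@@H](O)[C@H]2OC1` reaches only a limit of the assay, > 4000 nM. Within the data shown here, the single measured step, an at least 4.1-fold higher number from compound 1 to compound 2 (0.61 log units; beyond the scatter), alters the aryl ring that compound 3 `O=C1C=C(N2CCCCC2)C(=O)c2c1nc1n2[C@H]2OC[C@@H](O)[C@H]2OC1` removes entirely: piperidin-1-yl in place of (4-ethylphenyl)amino on a double-bonded ring carbon. That step bears only loosely on the new change, which also drops the hydrogen-bond donor and the aromatic ring. A weakening beyond the scatter is expected, a 3.1-fold higher number from compound 1 to compound 3 (0.49 log units; beyond the scatter). Compound 3 is estimated at 3000 nM, likely between 900 nM and 10000 nM.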

Compound 3, half-maximal inhibitory concentration: > 8000 nM
Compound 3: no number, only a limit (the forecaster's own chance of this, stated with the estimate: 40%); at least 2.6-fold (0.42 log units) between middle value and limit.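

Removing the whole aryl amine, not just altering a substituent on its ring as in compound 2, also weakens inhibition in this assay, with an at least 8.3-fold higher number from compound 1 to compound 3 (0.92 log units; beyond the scatter). So at this ring carbon, a saturated piperidin-1-yl does not replace (4-ethylphenyl)amino without loss. Compound 3 gives no true number, only a limit of the assay: the limit of > 8000 nM in this assay, at which 1 of the 3 values shown sits.

This single change removes both the aromatic ring and the hydrogen-bond donor, so their contributions cannot be separated. A cyclohexylamino group, which keeps the donor but has no aromatic ring, would help to tell them apart.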